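The source may report more compounds than this note shows. Statements on the series, on what has been measured and on what is new or still open speak of the compounds shown alone.

Compound 1 `Cc1nc2cc(C(=O)NN)c([N+](=O)[O-])cc2[nH]1` and compound 2 `Cc1nc2cc(C(=O)N/N=C\c3ccc(C)o3)c([N+](=O)[O-])cc2[nH]1` differ by one group; the step that the two limits leave unreadable from compound 1 to compound 2 cannot be read because both values are limits. In a functional assay on A549 cells (Homo sapiens) for cytotoxicity, read by resazurin assay, with a stated time of 72 h (a lower number here means a stronger inhibitor, a higher number a weaker inhibitor), compound 1 gives only a limit of the assay, > 100000 nM. In this assay compound 2 likewise gives only a limit, > 100000 nM. Both measured values sit at this limit (the limit of > 100000 nM in this assay, at which 2 of the 2 values shown sit). Compound 3 `Cc1nc2cc(C(=O)N/N=C\c3ccccn3)c([N+](=O)[O-])cc2[nH]1` differs from compound 2 by pyridin-2-yl in place of 5-methylfuran-2-yl on a carbon with a double bond to nitrogen. Going by the values given here, no measured step gives a size or direction for this change. Compound 3 is therefore expected at about 150000 nM, within 30000 nM to 1000000 nM, an estimated step that the limit leaves unreadable from compound 2 to compound 3.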

Compound 3, half-maximal inhibitory concentration: > 100000 nM
Compound 3: a limit, no number; the forecaster's own chance of this, stated with the estimate: 85%; the middle value is on the limit's open side.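

In this assay, going by these compounds alone, no step among compound 1, compound 2 and compound 3 can be read, since all three results are limits and not numbers: the limit of > 100000 nM in this assay, at which 3 of the 3 values shown sit. As far as these compounds go, how strong each of these three compounds actually is stays open, as does whether pyridin-2-yl or 5-methylfuran-2-yl gives the stronger inhibitor.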